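A few compounds are considered here, and "the series" means these few. Any claim that something is new, unique, unknown or untested is made for them only; others in the source may bear on it.

Measured compounds: compound 1 `c1ccc(-c2ccc(-c3ccc(-c4nc5ccccc5[nH]4)cc3)cc2)cc1`, 100000 nM in a functional assay on COLO 205 cells (Homo sapiens) for inhibition, read by sulforhodamine B assay; a higher number here means a weaker inhibitor of growth, a lower number a stronger inhibitor of growth; compound 2 `Fc1ccc(-c2ccc(-c3ccc(-c4nc5ccccc5[nH]4)cc3)cc2)cc1`, 100000 nM; compound 3 `Cc1ccc2[nH]c(-c3ccc(-c4ccc(-c5ccccc5)cc4)cc3)nc2c1`, 2560 nM.

The three share a chain of aromatic rings ending in a fused bicyclic core. Compound 3 differs from compound 1 by methyl in place of hydrogen on an aromatic carbon, and that single methyl carries the whole spread seen so far: a 39-fold lower number from compound 1 to compound 3 (1.59 log units; beyond the scatter). Compound 2 differs from compound 1 by fluoro in place of hydrogen on an aromatic carbon, and here the step is flat: no change at the digits printed from compound 1 to compound 2 (within the scatter).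

Compound 4 `Cc1ccc2[nH]c(-c3ccc(-c4ccc(-c5ccc(F)cc5)cc4)cc3)nc2c1` is not yet measured. It differs from compound 3 by fluoro in place of hydrogen on an aromatic carbon, the same change as from compound 1 to compound 2, at a place described in the same words. Compound 4 thus combines the methyl of compound 3 with the fluoro of compound 2.

In this assay compound 4 is expected to sit near compound 3, an estimated step of a 1.0-fold higher number from compound 3 to compound 4 (0.01 log units; within the scatter). Compound 4 is expected to give about 2600 nM because no change at the digits printed from compound 1 to compound 2 (within the scatter). The estimate for compound 4 spans 900 nM to 8000 nM, the wider range reflecting that the fluoro step has been seen only once.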

Compound 4, concentration for 50% growth inhibition: 100000 nM
The estimate for compound 4 lay 38-fold (1.59 log units) below the measured number; measured number outside the range, above it.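

The change from phenyl to 4-fluorophenyl gave a 39-fold higher number from compound 3 to compound 4 (1.59 log units; beyond the scatter) in this assay, so the fluoro step seen on the core of compound 1 did not carry over to the methyl-bearing core: the same change on two cores in this assay, no change at the digits printed (within the scatter) from compound 1 to compound 2 and a 39-fold higher number (1.59 log units; beyond the scatter) from compound 3 to compound 4, 39-fold (1.59 log units) apart, beyond the scatter of two such steps

The methyl step depended on its setting in the same way, giving no change at the digits printed from compound 2 to compound 4 (within the scatter), so it did not carry over from the core of compound 1 to the fluoro-bearing one: the same change on two cores in this assay, a 39-fold lower number (1.59 log units; beyond the scatter) from compound 1 to compound 3 and no change at the digits printed (within the scatter) from compound 2 to compound 4, 39-fold (1.59 log units) apart, beyond the scatter of two such steps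

These four compounds show that neither change can be transferred as a fixed step in this small set, where the gain appears only in compound 3, but they do not show why the two changes fail to add up or whether this holds beyond this one set.

As far as these compounds go, it remains open whether chloro, methoxy or an amine in place of the fluoro would also cancel the gain seen with the methyl. From the compounds shown here alone, it is equally open whether an ethyl group or a longer chain in place of the methyl would give a step like that of the methyl.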